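The compounds below may be only part of what the source reports. "The series", "measured", "known", "first", "only" and "open" are said of these compounds alone.

Measured in a functional assay on NCI-H1299 cells (Homo sapiens) for antiproliferative activity, read by MTT assay, with a stated time of 72 h; a lower number here means a stronger inhibitor, a higher number a weaker inhibitor:

Compound 1 `CCOC1=C(C(=O)c2ccccc2)C(c2ccc(Br)cc2)N(CCCn2ccnc2)C1=O` gives 28900 nM
Compound 2 `CCCCOC1=C(C(=O)c2ccccc2)C(c2ccc(Br)cc2)N(CCCn2ccnc2)C1=O` gives 17100 nM
Compound 3 `O=C(C1=C(Nc2ccc(F)cc2)C(=O)N(CCCn2ccnc2)C1c1ccc(Br)cc1)c1ccccc1` gives 25400 nM

Compound 2 holds the lowest of the three numbers in this assay, yet its nearest neighbour, compound 3, sits only a 1.5-fold higher number from compound 2 to compound 3 (0.17 log units; within the scatter), and compound 1 only a 1.7-fold lower number from compound 1 to compound 2 (0.23 log units; within the scatter), so all three stand within the scatter of one another and no order among them can be claimed.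

The next compound, compound 4 `O=C(C1=C(Nc2ccc(OC(F)(F)F)cc2)C(=O)N(CCCn2ccnc2)C1c1ccc(Br)cc1)c1ccccc1`, differs from compound 2 by (4-(trifluoromethoxy)phenyl)amino in place of butoxy on a double-bonded ring carbon.

Going by the values given here, two measured steps bear on this change. The step of a 1.5-fold higher number from compound 2 to compound 3 (0.17 log units; within the scatter) is the closest analogue, replacing the same butoxy with an anilino group, and it stayed within the scatter. The step of a 1.1-fold lower number from compound 1 to compound 3 (0.06 log units; within the scatter), the same type of exchange from a shorter alkoxy, was likewise within the scatter. Nothing in the series separates an anilino bearing a 4-fluoro substituent from one bearing a 4-(trifluoromethoxy) substituent, so no further guidance exists for that part of the change.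

On this basis compound 4 is expected to stay close to compound 2, with the estimated step of a 1.3-fold higher number from compound 2 to compound 4 (0.11 log units; within the scatter), not beyond the scatter. The estimate for compound 4 in this assay is 22000 nM, with a range from 9000 nM to 55000 nM.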

Compound 4, half-maximal inhibitory concentration: 11500 nM
The estimate for compound 4 lay 1.9-fold (0.28 log units) above the measured number; low and high end bracket the measured number.
By their numbers in this assay, from the lowest: compounds 4, 2, 3 and 1 (each within the scatter of the next, the first and the last beyond it).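

In this assay, going by these compounds alone, the aromatic substituent on the anilino group is the first change to produce a step beyond the scatter: trifluoromethoxy in place of fluoro gives a modest shift (a 2.2-fold lower number from compound 3 to compound 4 (0.34 log units; beyond the scatter)), so the group at this double-bonded ring carbon is not indifferent to what the aromatic ring carries. The (4-(trifluoromethoxy)phenyl)amino group also separates from ethoxy (a 2.5-fold lower number from compound 1 to compound 4 (0.40 log units; beyond the scatter)), but it does not separate from butoxy (a 1.5-fold lower number from compound 2 to compound 4 (0.17 log units; within the scatter)), which leaves compound 2 and compound 4 indistinguishable and limits any advantage of this group to the comparisons with compound 1 and compound 3. No measurement in hand bears on the reason for these steps.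

From the compounds shown here alone, it remains open whether the shift from fluoro to trifluoromethoxy belongs to a wider trend on the aromatic ring, since only two substituents are available there and neither an unsubstituted phenylamino group nor a ring carrying a carboxylic acid or an amine can be compared. Also open, going by these compounds, is whether a longer alkoxy chain than butoxy would stay level with the (4-(trifluoromethoxy)phenyl)amino group at this position.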